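The compounds below may be only part of what the source reports. "The series", "measured", "known", "first", "only" and "open" are said of these compounds alone.

Compound 1 `Nc1[nH]c(C(=O)c2ccccc2)c(-c2ccc(Cl)cc2Cl)c1C(=O)c1ccccc1` carries a phenyl on each carbonyl carbon. In an assay for inhibition of Polyunsaturated fatty acid lipoxygenase ALOX15 (Homo sapiens), with a stated time of 10 min (a lower number here means a stronger inhibitor, a higher number a weaker inhibitor), compound 1 gives > 100000 nM, which is a limit of the assay and not a number. Compound 2 `Nc1[nH]c(C(=O)c2ccccc2)c(-c2ccc(Cl)cc2Cl)c1C(=O)c1cccs1` differs from it by a thiophen-2-yl in place of phenyl on a carbonyl carbon. In this assay compound 2 gives > 100000 nM, again a limit of the assay rather than a number. The step that the two limits leave unreadable from compound 1 to compound 2 cannot be read from the two limits; both values sit at the limit of > 100000 nM in this assay, at which 2 of the 2 values shown sit, so compound 2 stands at the limit with no measured number beside it. Compound 3 `Cc1cccc(C(=O)c2c(N)[nH]c(C(=O)c3ccccc3)c2-c2ccc(Cl)cc2Cl)c1` continues from compound 2 by 3-methylphenyl in place of thiophen-2-yl on a carbonyl carbon. Among the measured compounds shown here, the one measured step, a step that the two limits leave unreadable from compound 1 to compound 2, concerns the same carbonyl position but has no readable size, so neither a direction nor a size can be drawn from it for this change. With two limits and no readable step, compound 3 is expected to remain in the same region, and the step that the limit leaves unreadable from compound 2 to compound 3 is estimated to be small. Compound 3 is therefore estimated at 200000 nM in this assay, with a range of 50000 nM to 1000000 nM.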

Compound 3, half-maximal inhibitory concentration: > 100000 nM
Compound 3: a limit, no number (the forecaster's own chance of this, stated with the estimate: 85%); the middle value lies beyond the limit too.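

In this assay compound 3 gives > 100000 nM, a limit of the assay and not a number. No step among compound 1, compound 2 and compound 3 can be read, since all three share one limit: the limit of > 100000 nM in this assay, at which 3 of the 3 values shown sit.

The compounds shown leave open whether any group on the carbonyl carbon gives a measurable value in this assay.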